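The compounds below may be only part of what the source reports. "The series", "measured", "known", "first", "only" and "open" are said of these compounds alone.

Compound 3, `N#C/C(=C\c1c(-c2ccccc2)[nH]c2ccccc12)S(=O)(=O)c1ccccc1`, gives 652 nM in a functional assay on KM12 cells (Homo sapiens) for inhibition, read by sulforhodamine B assay, with a stated time of 48 h (a lower number here means a stronger inhibitor of growth, a higher number a weaker inhibitor of growth), the lowest of the three numbers in hand. Its nearest neighbour is compound 1, `CC(=O)/C(=C\c1c(-c2ccccc2)[nH]c2ccccc12)S(=O)(=O)c1ccccc1`, at 1000 nM; the step of a 1.5-fold lower number from compound 1 to compound 3 (0.19 log units; within the scatter) stays within the scatter. The furthest is compound 2, `COc1ccc2[nH]c(-c3ccccc3)c(/C=C(\C#N)S(=O)(=O)c3ccccc3)c2c1`, at 3000 nM; the step of a 4.6-fold lower number from compound 2 to compound 3 (0.66 log units; beyond the scatter) is beyond the scatter but modest.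

Compound 4, `N#C/C(=C\c1c(-c2ccccc2)[nH]c2ccccc12)C(=O)c1ccccc1`, is reached from compound 3 by a single change: benzoyl in place of phenylsulfonyl on a double-bonded chain carbon bound to a double-bonded chain carbon and a triple-bonded carbon. Neither measured step touches this part of the molecule. For the measured compounds named here, the step from compound 1 to compound 3 exchanges the group on the other chain carbon, and the step from compound 2 to compound 3 concerns the aromatic ring of the shared core, so no direct precedent exists for exchanging the phenylsulfonyl. Going by the values given here, the only guide is that the one change at the chain so far, from compound 1 to compound 3, stayed within the scatter, while the ring change was modest. On this basis compound 4 is expected to give a number near compound 3, with a step of a 1.5-fold higher number from compound 3 to compound 4 (0.19 log units; within the scatter) that is not expected to exceed the scatter by much in either direction. The estimate for compound 4 in this assay is 1000 nM, with a range of 300 nM to 3500 nM.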

Compound 4, concentration for 50% growth inhibition: 2000 nM
The estimate for compound 4 lay 2.0-fold (0.30 log units) below the measured number; low and high end bracket the measured number.
By their numbers in this assay, from the lowest: compounds 3, 1, 4 and 2 (each within the scatter of the next, the first and the last beyond it).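

In this assay, for the compounds shown here, the exchange at this carbon is the first change on the chain to go beyond the scatter: a 3.1-fold higher number from compound 3 to compound 4 (0.49 log units; beyond the scatter) stands against the only earlier chain step, a 1.5-fold lower number from compound 1 to compound 3 (0.19 log units; within the scatter), which stayed within it. This position therefore responds to the choice of group, and phenylsulfonyl gives the lower number of the two groups compared here in otherwise identical compounds. The step is modest, as is the ring change a 4.6-fold lower number from compound 2 to compound 3 (0.66 log units; beyond the scatter), so benzoyl in place of phenylsulfonyl shifts the number without taking compound 4 out of the measurable range, and nothing in hand accounts for the difference between the two groups.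

With only phenylsulfonyl and benzoyl compared on a double-bonded chain carbon bound to a double-bonded chain carbon and a triple-bonded carbon, the compounds shown leave open whether the sulfonyl or the attached phenyl ring matters more, which a methylsulfonyl, a sulfonamide or an amide at this carbon would begin to separate. They also leave open whether the same exchange gives a step of similar size on the methoxy-bearing core of compound 2 or alongside the acetyl group of compound 1.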